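From cyano to methyl on compound 3

The source may report more compounds than this note shows. Statements on the series, on what has been measured and on what is new or still open speak of the compounds shown alone.

Compound 1 `O=c1c(O)cccn1Cc1ccccc1`: > 10 ug/mL
Compound 2 `N#Cc1ccc(-c2ccc(Cn3cccc(O)c3=O)cc2)cc1`: > 10 ug/mL
Compound 3 `N#Cc1cccc(-c2ccc(Cn3cccc(O)c3=O)cc2)c1`: > 10 ug/mL

In an ADME assay on THP-1 cells (Homo sapiens) for cytotoxicity, read by resazurin assay, with a stated time of 48 h (a higher number here means a weaker inhibitor, a lower number a stronger inhibitor), compound 3 gives > 10 ug/mL, which is a limit and not a number. The measured compounds share one position: the limit of > 10 ug/mL in this assay, at which 3 of the 3 values shown sit. Compound 4 `Cc1cccc(-c2ccc(Cn3cccc(O)c3=O)cc2)c1` differs from compound 3 by having methyl in place of cyano on an aromatic carbon, meta to a large group: methyl in place of cyano on an aromatic carbon. For the measured compounds named here, no measured pair differs in one place, so the data show no step size for such a change. In this assay no change beyond the scatter is expected, in either direction. The estimated step is a step that the limit leaves unreadable from compound 3 to compound 4. A further limit is the most likely report. For compound 4 the estimate is 15 ug/mL, with an expected range from 6 ug/mL to 40 ug/mL.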

Compound 4, half-maximal inhibitory concentration: > 10 ug/mL
Compound 4: no number, only a limit; the forecaster's own chance of this, stated with the estimate: 80%; the middle value does not contradict the limit.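

No step can be read from compound 3 to compound 4, or from compound 1 to compound 4, because each value is only a limit: the limit of > 10 ug/mL in this assay, at which 4 of the 4 values shown sit.

The compounds shown leave open where each one's actual value lies in this assay, and so whether methyl and cyano differ there.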